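Methoxy for chloro on compound 1: expected downward step

A few compounds are considered here, and "the series" means these few. Any claim that something is new, unique, unknown or untested is made for them only; others in the source may bear on it.

Of the compounds shown here, three on one shared core have been measured in a physicochemical assay for lipophilicity, read by HPLC, at pH 7.4; a higher number here means a more lipophilic compound, a lower number a more polar compound. Compound 1 `NCc1csc(NC(=O)c2ccc(Cl)cc2)n1` gives 1.6 and stands highest of the three numbers. Compound 3 `NCc1csc(NC(=O)c2cc3ccccc3[nH]2)n1` gives 1.4 in this assay, a value within the scatter of compound 1, so no order between these two is read. Compound 2 `NCc1csc(NC(=O)c2cnn[nH]2)n1` gives -0.3, a number far beneath compound 1 and well beyond the scatter. Going by the values given here, no two of the measured compounds differ in a single place, so no measured single step is available for the series.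

Compound 4 `COc1ccc(C(=O)Nc2nc(CN)cs2)cc1` awaits measurement in this assay. It differs from compound 1 in one place: methoxy in place of chloro on an aromatic carbon. With no measured step of this kind in hand, the expectation rests on compound 1 alone and on the nature of the exchange, with the only reference point at 1.6 for compound 1.

The step is expected to run downward and beyond the scatter, estimated as a number 0.70 log units lower from compound 1 to compound 4 (beyond the scatter). Compound 4 is estimated at 0.9, with a range from 0.5 to 1.3.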

Compound 4, distribution coefficient: 1.2
For compound 4 the middle estimate is 0.30 log units below the measured one, within the range that was stated.
By their numbers in this assay, from the lowest: compound 2; then compounds 4, 3 and 1 (each within the scatter of the next, the first and the last beyond it).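

In this assay the series now has its first measured step in a single place: a number 0.40 log units lower from compound 1 to compound 4 (beyond the scatter) is what methoxy in place of chloro gives on an aromatic carbon, para to a large group. Compounds 1, 2 and 3 differ from one another in more than one place, so they could not show that a change of this one substituent, with the rest of compound 1 held fixed, moves the number beyond the scatter. No measurement of any property of either group bears on this step, so the size and direction of the change stand here as an observation without an explanation.

A single exchange at this position leaves open how other groups in the same place, such as an amine, a carboxylic acid, a hydroxyl or a longer chain like ethoxy, would compare with chloro and methoxy, and whether any would give a larger step. It also leaves open whether methoxy in place of chloro gives a step of similar size on another carbon of the same ring, or whether this one result holds only for the position and the core of compound 1.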